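The source may hold more compounds than are shown below. What is called first, only, known or untested is meant among the compounds shown, and "the series" means these compounds.

Measured compounds:
- Compound 1 `CCOC(=O)C1=Cc2ccccc2OC1(OCc1cn(CC(=O)Nc2cccc(Cl)c2)nn1)C(F)(F)F` gives 12300 nM in a functional assay on HeLa cells (Homo sapiens) for inhibition, read by MTT assay, with a stated time of 24 h; a higher number here means a weaker inhibitor, a lower number a stronger inhibitor.
- Compound 2 `CCOC(=O)C1=Cc2ccccc2OC1(OCc1cc(-c2ccc3ccccc3c2)no1)C(F)(F)F` gives > 150000 nM in this assay, which is a limit of the assay rather than a number.

Going by the values given here, compound 1 carries the only actual number among the two measured compounds, and that number marks it as a weak inhibitor. Among the compounds with values here, of compound 2 only a limit is known, described by the limit of > 150000 nM in this assay, at which 1 of the 2 values shown sits, so no step between compound 1 and compound 2 can be sized; the two values show only that compound 2 reached no measurable inhibition where compound 1 did.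

Compound 3 `CCOC(=O)C1=Cc2ccccc2OC1(OCc1cn(-c2ccc(F)c([N+](=O)[O-])c2)nn1)C(F)(F)F` is not yet measured. It differs from compound 1 in one place: 4-fluoro-3-nitrophenyl in place of ((3-chlorophenyl)carbamoyl)methyl on an aromatic nitrogen. The change removes the group bearing the hydrogen-bond donor and places a smaller, fully aromatic group directly on the ring nitrogen. Within the data shown here, no measured step of this kind exists here to lean on.

With only compound 1 as an anchor, the expected step from compound 1 to compound 3 is a 1.8-fold higher number from compound 1 to compound 3 (0.25 log units; within the scatter), toward a somewhat weaker inhibitor, though a result within the scatter would not surprise. The estimate for compound 3 in this assay is therefore 22000 nM, with a range from 6000 nM to 90000 nM.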

Compound 3, half-maximal inhibitory concentration: 15600 nM
Compound 3: the middle estimate sits 1.4-fold (0.15 log units) above what was measured; the range from low to high includes it.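

Placing 4-fluoro-3-nitrophenyl on the aromatic nitrogen in place of ((3-chlorophenyl)carbamoyl)methyl gives a 1.3-fold higher number from compound 1 to compound 3 (0.10 log units; within the scatter) in this assay and so leaves the two compounds indistinguishable in this read-out. At this position, a group with a hydrogen-bond donor and a group with none give values within the scatter of each other, so for this pair neither the amide hydrogen nor the carbamoyl link is needed to keep this weak level of inhibition. Nothing measured among these compounds explains why two such different groups read alike.

As far as these compounds go, the fluorine and the nitro group enter together, so the share of each in the value of compound 3 remains unknown, and the same holds for the chlorine in compound 1. Also open, from the compounds shown here alone, is how a different kind of group on this nitrogen would read, such as a carboxylic acid or a longer chain ending in an amine, and whether any group here can bring the number well down from this weak range.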